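One Added Methyl on a Compound Held at a Limit

A few compounds are considered here, and "the series" means these few. Any claim that something is new, unique, unknown or untested is made for them only; others in the source may bear on it.

Measured in an ADME assay on MT4 cells (Homo sapiens) for cytotoxicity, read by MTT assay, with a stated time of 96 h; on this read-out lower numbers stand for higher toxicity in this test and higher numbers for lower toxicity in this test:
- Compound 1 `Brc1ccc(NCc2cn(-c3ccccc3)nc2-c2ccccc2)cc1`: > 100000 nM
- Compound 2 `Cc1ccc(NCc2cn(-c3ccccc3)nc2-c2ccccc2)cc1`: > 100000 nM

Neither entry is a true number, and the limit of > 100000 nM in this assay, at which 2 of the 2 values shown sit, applies to both. Compound 1 therefore stands at a limit of the assay, > 100000 nM, and its exact value is not known.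

Compound 3 `Cc1ccc(-c2nn(-c3ccccc3)cc2CNc2ccc(Br)cc2)cc1` has not yet been measured. It differs from compound 1 by methyl in place of hydrogen on an aromatic carbon, para to a large group: methyl in place of hydrogen on an aromatic carbon.

Among the compounds with values here, only one measured step bears on this change: a step that the two limits leave unreadable from compound 1 to compound 2. It also brings in a methyl on an aromatic carbon, but there the methyl replaces bromo, and the step has no readable size. It therefore gives only weak guidance, and no step beyond the scatter is expected in this assay. Another limit is the most likely result, and any readable number is expected to fall on the lower side. The expected change is an at least 1.1-fold lower number from compound 1 to compound 3 (0.04 log units; that floor lies within the scatter). For compound 3 the estimated value is 90000 nM, with an expected range from 40000 nM to 100000 nM.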

Compound 3, half-maximal cytotoxic concentration: > 100000 nM
Compound 3: no number, only a limit; the forecaster's own chance of this, stated with the estimate: 65%; middle value at least 1.1-fold (0.04 log units) away from the limit.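

Compound 3 gives > 100000 nM in this assay, and this entry is a limit, not a number. No step can be read among compound 1, compound 2 and compound 3, because all three entries are limits: the limit of > 100000 nM in this assay, at which 3 of the 3 values shown sit.

The compounds shown leave open how far the true values lie beyond the limit and whether the added methyl changes cytotoxicity at all.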